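The source may hold more compounds than are shown below. What is called first, only, known or untested is meant among the compounds shown, and "the series" means these compounds.

Three compounds have been measured in an ADME assay on RAW264.7 cells (Mus musculus) for cytotoxicity, read by MTT assay, with a stated time of 72 h, tested at 50 uM; a lower number here means less inhibition, a higher number more inhibition at the concentration tested (going by the name of the read-out):

Compound 1, `CCOC(=O)c1sc(-c2ccccn2)nc1N1CCC(NCc2cccc(C(F)(F)F)c2)CC1`, gives 19.2%.
Compound 2, `CCOC(=O)c1sc(-c2ccccn2)nc1N1CCC(NCc2ccc(Cl)c(Cl)c2)CC1`, gives 30.1%.
Compound 3, `CCOC(=O)c1sc(-c2ccncc2)nc1N1CCC(NCc2cccc(C(F)(F)F)c2)CC1`, gives 14.3%.

Compound 1 and compound 2 share a core and differ in one place, (3,4-dichlorophenyl in place of 3-(trifluoromethyl)phenyl on a saturated chain carbon bound to an amine nitrogen). That exchange made a step of a number 10.9 percentage points higher from compound 1 to compound 2 (beyond the scatter), a modest rise in this assay that lies beyond the usual scatter. Compound 1 and compound 3 in turn differ only in the core, (pyridin-4-yl in place of pyridin-2-yl on an aromatic carbon), and that exchange gave a number 4.9 percentage points lower from compound 1 to compound 3 (within the scatter), which lies within the scatter, so compound 1 and compound 3 cannot be told apart in this assay on this evidence.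

Compound 4, `CCOC(=O)c1sc(-c2ccncc2)nc1N1CCC(NCc2ccc(Cl)c(Cl)c2)CC1`, has not yet been measured. It carries the core of compound 3 and differs from compound 3 by 3,4-dichlorophenyl in place of 3-(trifluoromethyl)phenyl on a saturated chain carbon bound to an amine nitrogen. Within the data shown here, the place of this change is worded identically for both pairs, so it is the same change as the one from compound 1 to compound 2, made on the other core. Since that earlier change gave a number 10.9 percentage points higher from compound 1 to compound 2 (beyond the scatter), and the two cores themselves showed only a number 4.9 percentage points lower from compound 1 to compound 3 (within the scatter), the step from compound 3 to compound 4 is expected to be of a similar size, estimated at a number 10.7 percentage points higher from compound 3 to compound 4 (beyond the scatter). Compound 4 is therefore expected to reach about 25% in this assay, with a plausible range from 14% to 37%, resting on a single prior instance of the change.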

Compound 4, a percentage reported as inhibition, at one concentration (the size of the read-out at that concentration, not a potency): 32.2%
The estimate for compound 4 lay 7.2 percentage points below the measured number; the range from low to high includes it.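

In this assay, putting 3,4-dichlorophenyl in place of 3-(trifluoromethyl)phenyl on the second core gave a number 17.9 percentage points higher from compound 3 to compound 4 (beyond the scatter), and this step agrees with the one seen on the first core: the same change on two cores in this assay, a number 10.9 percentage points higher (beyond the scatter) from compound 1 to compound 2 and a number 17.9 percentage points higher (beyond the scatter) from compound 3 to compound 4, 7 percentage points apart, within the scatter of two such steps. The other exchange, pyridin-4-yl in place of pyridin-2-yl, gave a number 2.1 percentage points higher from compound 2 to compound 4 (within the scatter) with the 3,4-dichlorophenyl group in place, and it stays within the scatter with either group: the same change on two cores in this assay, a number 4.9 percentage points lower (within the scatter) from compound 1 to compound 3 and a number 2.1 percentage points higher (within the scatter) from compound 2 to compound 4, 7 percentage points apart, within the scatter of two such steps. Within these four compounds, then, the change of aryl group carried over from one core to the other, raising the number on both while the position of the pyridine nitrogen made no measurable difference, but this rests on only two instances on closely related cores and does not show that the change would behave the same way on a more distant core, nor does it explain why it raises the number.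

These compounds leave open what a plain phenyl group would do on the same chain, or what a carboxylic acid or an amide would do in place of the ethyl ester. They also leave open how the compounds compare at other concentrations, since each number here is a single reading at one concentration and not a potency.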